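A few compounds are considered here, and "the series" means these few. Any claim that something is new, unique, unknown or untested is made for them only; others in the source may bear on it.

Three compounds share one core, a carboxylic acid-bearing bicyclic amidine carrying an aryl ether side arm. In an assay on isolated protein for agonist activity at Bile acid receptor (Homo sapiens), read by TR-FRET (a lower number here means that less compound is needed, a higher number that more compound is needed for the effect), compound 1 `CC(C)c1onc(-c2c(Cl)cccc2Cl)c1COc1ccc(-c2nc3ccc(C(=O)O)cc3n2CC2CCCCC2)c(F)c1` gives "not determined" (no result reported), so no result is reported for it. Within the data shown here, compound 2 `CC(C)c1onc(-c2c(Cl)cccc2Cl)c1COc1ccc(-c2nc3ccc(C(=O)O)cc3n2CC(C)(C)C)cc1` is the one compound with a number: in this assay compound 2 gives 24.8 nM, so compound 2 stands as the only measured point, with nothing to compare it against.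

Compound 3 `CCCn1c(-c2ccc(OCc3c(-c4c(Cl)cccc4Cl)noc3C(C)C)cc2)nc2ccc(C(=O)O)cc21` differs from compound 2 in one place: ethyl in place of tert-butyl on a saturated chain carbon bound to an aromatic nitrogen. Cut one bond further out, the same change reads neopentyl to propyl. Among the measured compounds shown here, no measured pair shows what such a shortening does here, so the expected step is guessed, not derived. A modest weakening is expected, close to the edge of the usual scatter, so a 1.8-fold higher number from compound 2 to compound 3 (0.26 log units; within the scatter) is the estimated step. Compound 3 is expected to give about 45 nM in this assay, within a range from 12 nM to 160 nM.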

Compound 3, half-maximal effective concentration: 96.4 nM
For compound 3 the middle estimate is 2.1-fold (0.33 log units) below the measured one, and the stated range covers the measured number.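

Shortening this group is not neutral: ethyl in place of tert-butyl on a saturated chain carbon bound to an aromatic nitrogen gives a 3.9-fold higher number from compound 2 to compound 3 (0.59 log units; beyond the scatter) in this assay. This first measured pair therefore shows that the size of the group at this place can shift the result by more than the usual scatter, with the larger group of compound 2 needing less compound for the effect. Nothing measured here explains the shift.

Among these compounds, with only two numbers at this place, they cannot show whether the result changes steadily with chain size or whether tert-butyl is a special case. On these data alone, how a longer chain such as butyl, a ring such as cyclopropyl, or a chain carrying an amine would behave at the same place remains open.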